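This account rests on a few compounds, and the source may have more. Where it says the series, first, only, none or still open, it means among the compounds named here.

Compound 2 `COc1ccc([C@H]2CC(=O)N(c3cccc(N(C)C)c3)C2)cc1OC1CCCC1` stands at the top of the measured range. In a functional assay on HEK293 cells (Homo sapiens) for cytotoxicity (a lower number here means that less compound is tolerated, a higher number that more compound is tolerated), compound 2 gives only the assay limit of > 10000 nM. Compound 1 `COc1ccc([C@H]2CC(=O)N(C(=O)c3ccccc3)C2)cc1OC1CCCC1` gives in this assay the limit > 10000 nM as well. The step that the two limits leave unreadable from compound 1 to compound 2 is therefore not readable, and the limit of > 10000 nM in this assay, at which 2 of the 2 values shown sit, is the whole measured record. Compound 3 `COc1ccc([C@H]2CC(=O)N(c3cccc(NS(=O)(=O)c4ccccc4Cl)c3)C2)cc1OC1CCCC1` differs from compound 2 by ((2-chlorophenyl)sulfonyl)amino in place of dimethylamino on an aromatic carbon. For the measured compounds named here, no measured step bears readably on this change. Compound 3 is expected to remain at the limit, estimated at 15000 nM with a range of 7000 nM to 40000 nM. The expected step is a step that the limit leaves unreadable from compound 2 to compound 3, none beyond the scatter.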

Compound 3, half-maximal cytotoxic concentration: > 10000 nM
Compound 3 was reported as a limit; the forecaster's own chance of this, stated with the estimate: 80%; the middle value lies beyond the limit too.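

Compound 2 and compound 3 both give only a limit in this assay, so no step between them can be read: the limit of > 10000 nM in this assay, at which 3 of the 3 values shown sit.

The compounds shown leave open at what concentration any of them would reach half-maximal cytotoxicity.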